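The source may report more compounds than this note shows. Statements on the series, on what has been measured and on what is new or still open speak of the compounds shown alone.

Of the compounds shown here, three built on the same core have been measured so far. Compound 3 (`COc1cc(/C=C/C(=O)c2ccc(N)c(-c3ccc(F)cc3)c2)cc(OC)c1OC`) gives 6070 nM in a functional assay on A549 cells (Homo sapiens) for cytotoxicity, read by sulforhodamine B assay, with a stated time of 48 h (on this read-out higher numbers stand for weaker inhibition and lower numbers for stronger inhibition), the middle of the three numbers. Compound 2 (`COc1cc(/C=C/C(=O)c2ccc(N)c(-c3ccc(F)cc3)c2)ccc1O`) at 12200 nM lies within the usual scatter of that value, so the two cannot be told apart. Compound 1 (`COc1ccc(/C=C/C(=O)c2ccc(N)c(-c3ccc(F)cc3)c2)cc1O`) at 940 nM has a clearly lower number, meaning stronger inhibition.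

Compound 4 (`COc1ccc(/C=C/C(=O)c2ccc(N)c(-c3ccc(F)cc3)c2)cc1OC`) differs from compound 3 in one place, with hydrogen in place of methoxy on an aromatic carbon. Among the measured compounds shown here, no measured step makes this exact change, so the evidence is indirect. For the measured compounds named here, the only measured step (a 13-fold higher number from compound 1 to compound 2 (1.11 log units; beyond the scatter)) is large, yet it merely exchanges 3-hydroxy-4-methoxyphenyl for 4-hydroxy-3-methoxyphenyl. It removes no methoxy, so it gives no direction for compound 4, but it does show that a modest change on this ring can move the number considerably. The starting point therefore stays with compound 3, with a wide margin on both sides. The expected step (a 1.3-fold lower number from compound 3 to compound 4 (0.13 log units; within the scatter)) is no shift beyond the scatter. The estimated value for compound 4 is 4500 nM, with an expected range from 1300 nM to 15000 nM in this assay.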

Compound 4, half-maximal inhibitory concentration: 8630 nM
Compound 4: middle estimate off by 1.9-fold (0.28 log units), on the low side; the range from low to high includes it.
By their numbers in this assay, from the lowest: compound 1; then compounds 3, 4 and 2 (each within the scatter of the next).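

In this assay, swapping this methoxy for hydrogen gives no change that can be told from scatter (a 1.4-fold higher number from compound 3 to compound 4 (0.15 log units; within the scatter)), so compounds with and without this group cannot be separated here. Compound 4 also shows that putting a methyl on a hydroxy oxygen has a different outcome depending on which hydroxy is capped: starting from the hydroxy of compound 2, the result stays within the scatter (a 1.4-fold lower number from compound 2 to compound 4 (0.15 log units; within the scatter)), whereas starting from the hydroxy of compound 1, the low number is lost (a 9.2-fold higher number from compound 1 to compound 4 (0.96 log units; beyond the scatter)). Nothing available explains why capping one oxygen matters and capping the other does not.

The compounds shown leave open whether the low number of compound 1 needs a free hydroxy at that spot, or whether an amine or a fluorine there would serve equally well. From the compounds shown here alone, it is also open how a longer chain on that oxygen, such as ethoxy, would compare with the methyl of compound 4, which would show whether any group on that oxygen costs this much.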